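The source may report more compounds than this note shows. Statements on the series, on what has been measured and on what is new or still open speak of the compounds shown alone.

Measured so far:
compound 1 `O=C1Nc2c(C(F)(F)F)cccc2C1(c1ccc(OC(F)(F)F)cc1)c1ccc(O)c(F)c1`: 33 nM
compound 2 `O=C1Nc2c(C(F)(F)F)cccc2C1(c1ccc(OC(F)(F)F)cc1)c1ccc(O)cc1F`: 177 nM

Both compounds were tested in a functional assay on MCF7 cells (Homo sapiens) for inhibition, read by resazurin assay, with a stated time of 24 h; on this read-out lower numbers stand for stronger inhibition and higher numbers for weaker inhibition. Of the two, compound 2 stands higher, at 177 nM, so it is the weaker inhibitor of the pair. The next compound to be tested is compound 3 `O=C1Nc2c(C(F)(F)F)cccc2C1(c1ccc(OC(F)(F)F)cc1)c1c(F)cc(O)cc1F`, which keeps the shared core and differs from compound 2 in one place: fluoro in place of hydrogen on an aromatic carbon. This is fluoro in place of hydrogen on an aromatic carbon, which turns 2-fluoro-4-hydroxyphenyl into 2,6-difluoro-4-hydroxyphenyl.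

Going by the values given here, the only measured step that bears on this change is a 5.4-fold higher number from compound 1 to compound 2 (0.73 log units; beyond the scatter), with 2-fluoro-4-hydroxyphenyl in place of 3-fluoro-4-hydroxyphenyl. That step is modest but real, and it produced the group that compound 3 now extends. Among the compounds with values here, no measured step adds a fluoro outright, so its direction is only a weak guide. A further rise of similar or smaller size in this assay is expected, and a result within the scatter would not surprise. The expected change is a 1.7-fold higher number from compound 2 to compound 3 (0.23 log units; within the scatter). For compound 3 the estimated value is 300 nM, with an expected range from 90 nM to 900 nM.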

Compound 3, half-maximal inhibitory concentration: 549 nM
For compound 3 the middle estimate is 1.8-fold (0.26 log units) below the measured one; the measured number falls inside the stated range.
By their numbers in this assay, from the lowest: compound 1; then compound 2; then compound 3.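

In this assay, the fluoro entering on the aromatic carbon ortho to a large group and meta to a hydroxy group gives a 3.1-fold higher number from compound 2 to compound 3 (0.49 log units; beyond the scatter), which shows that adding a fluoro outright to 2-fluoro-4-hydroxyphenyl moves the number beyond the scatter, something the earlier swap of one fluorinated ring for another could not show. Set against the ring of compound 1, 2,6-difluoro-4-hydroxyphenyl gives a 17-fold higher number from compound 1 to compound 3 (1.22 log units; beyond the scatter), the largest step among these compounds, so 3-fluoro-4-hydroxyphenyl keeps the lowest number of the three and each further change on this ring has so far raised it. Nothing available here accounts for the rise on adding this fluoro.

Going by these compounds, whether a chloro or a methyl group on the same aromatic carbon would raise the number as the fluoro does remains open, as does the effect of a second fluoro added to the ring of compound 1. On these data alone, it is also open whether this order would hold with an amine or a methoxy group in place of the hydroxy group.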